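Swapping the Aryl Ether for a Thioether on the Core

The source may hold more compounds than are shown below. What is called first, only, known or untested is meant among the compounds shown, and "the series" means these compounds.

Compound 1 `Nc1cc(N)c2nc(-c3ccccc3)c(Oc3ccc(Cl)c(Cl)c3)nc2c1` was tested in a functional assay on RXF 393 cells (Homo sapiens) for inhibition, read by sulforhodamine B assay, with a stated time of 48 h; a higher number here means that more compound is tolerated, a lower number that less compound is tolerated. In this assay compound 1 gives < 100000 nM, which is a limit of the assay rather than a number. Two further compounds share the core of compound 1. Compound 2 `CCOC(=O)[C@H](CCC(=O)O)NC(=O)c1ccc(Sc2nc3cc(N)cc(N)c3nc2-c2ccccc2)cc1` gives < 100000 nM in this assay, again only a limit. Compound 3 `CCOC(=O)[C@H](CCC(=O)O)NC(=O)c1ccc(Oc2nc3cc(N)cc(N)c3nc2-c2ccccc2)cc1` gives < 50200 nM in this assay, also a limit. Compound 1 therefore stands at the limit of < 100000 nM in this assay, at which 2 of the 3 values shown sit, and the only other reading shown is the limit of < 50200 nM in this assay, at which 1 of the 3 values shown sits. Within the data shown here, every value here is a limit, so no step between measured compounds can be counted.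

Compound 4 `COc1ccc(Sc2nc3cc(N)cc(N)c3nc2-c2ccccc2)cc1` has not yet been measured. It differs from compound 1 by (4-methoxyphenyl)sulfanyl in place of 3,4-dichlorophenoxy on an aromatic carbon. With nothing but limits in hand, the step from compound 1 to compound 4 is expected to stay within the usual scatter, and is estimated as a step that the limit leaves unreadable from compound 1 to compound 4. Compound 4 is expected to give about 40000 nM in this assay, with a likely range from 8000 nM to 100000 nM, and a real chance that the assay once more reports only a limit.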

Compound 4, concentration lethal to 50% of the cells: < 100000 nM
Compound 4: only a limit was reported; the forecaster's own chance of this, stated with the estimate: 55%; the middle value is on the limit's open side.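

In this assay compound 1 and compound 4 both give only a limit, so no step can be read between them. Most values shown sit at one limit: the limit of < 100000 nM in this assay, at which 3 of the 4 values shown sit.

The compounds shown leave open what the actual lethal concentration is, and whether this swap changes it at all.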